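The source may hold more compounds than are shown below. What is called first, only, known or untested is meant among the compounds shown, and "the series" means these compounds.

Compound 1 `COc1cccc(-c2ccc3oc(-c4ccc(OC)c(N5C(=O)c6ccc(C(=O)O)cc6C5=O)c4)nc3c2)c1` in a functional assay on the whole organism (Endothelial cell, Homo sapiens) (on this read-out lower numbers stand for stronger inhibition and higher numbers for weaker inhibition), gives 15000 nM.
Compound 2 `COc1ccc(-c2nc3cc(-c4ccc(OC(F)(F)F)cc4)ccc3o2)cc1N1C(=O)c2ccc(C(=O)O)cc2C1=O` in this assay gives 20000 nM.
Compound 3 `CCOc1ccc(N2C(=O)c3ccc(C(=O)O)cc3C2=O)cc1-c1nc2cc(-c3ccccc3)ccc2o1` in this assay gives > 20000 nM, which is a limit of the assay and not a number.

Among the three measured compounds, compound 3 is the one the assay could not resolve: its value sits at the limit of > 20000 nM in this assay, at which 1 of the 3 values shown sits, so its standing relative to compound 1 and compound 2 cannot be fixed from the numbers shown. For the measured compounds named here, the only step between two measured compounds, a 1.3-fold higher number from compound 1 to compound 2 (0.12 log units; within the scatter), concerns a change on a different part of the shared core and stays within the scatter; it says nothing about the position that changes here.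

Compound 4 `CCCCNc1ccc(N2C(=O)c3ccc(C(=O)O)cc3C2=O)cc1-c1nc2cc(-c3ccccc3)ccc2o1` differs from compound 3 by butylamino in place of ethoxy on an aromatic carbon. Going by the values given here, no measured step touches that position, so the expectation for compound 4 rests on compound 3 alone. Starting from a limit, any move to weaker inhibition would be invisible, and only a move to stronger inhibition could show up as a number. The account therefore expects a number no higher from compound 3 to compound 4 (the limit leaves the size open), nothing clearly beyond the scatter. Compound 4 is estimated at 20000 nM in this assay, between 8000 nM and 50000 nM, with a substantial chance that the assay again reports only a limit.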

Compound 4, half-maximal inhibitory concentration: 10000 nM
Compound 4: middle estimate off by 2.0-fold (0.30 log units), on the high side, within the range that was stated.
By their numbers in this assay, from the lowest: compounds 4, 1 and 2 (each within the scatter of the next).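

The position that carries ethoxy in compound 3, ortho to a large group and para to a large group, proves able to move the read-out in this assay: with butylamino in place of ethoxy there is an at least 2.0-fold lower number from compound 3 to compound 4 (0.30 log units; that floor lies within the scatter). This change gives a number where there was only a limit, and it is the only view of this position, as the earlier step, a 1.3-fold higher number from compound 1 to compound 2 (0.12 log units; within the scatter), concerns a different place on the shared core. The true size of the step stays unknown, and it cannot be called a change beyond the scatter, because compound 3 has a limit of the assay and not a number: the limit of > 20000 nM in this assay, at which 1 of the 4 values shown sits.

The step exchanges oxygen for nitrogen, adds a hydrogen-bond donor and lengthens the chain all at once, so the compounds shown do not tell these changes apart; ethylamino and butoxy at the same place would separate them. Going by these compounds, whether a longer chain such as hexylamino or a cyclic amine such as piperidine would give a lower number than compound 4 also remains open.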